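Moving a chlorine atom on a sulfur-linked benzyl arm

The source may report more compounds than this note shows. Statements on the series, on what has been measured and on what is new or still open speak of the compounds shown alone.

Compound 1, `CC1=C(C(=O)Nc2ccc([N+](=O)[O-])cc2)C(c2ccc(Br)cc2)N=C(SCc2cccc(Cl)c2)N1`, gives 11.8% in a functional assay on the whole organism (artery, strain albino) with Rattus norvegicus as the target, with a stated time of 240 min, at a dose of 10 mg/kg by the oral route; on this read-out lower numbers stand for less inhibition and higher numbers for more inhibition at the one dose given (going by the name of the read-out).
Compound 2, `CC1=C(C(=O)Nc2ccc([N+](=O)[O-])cc2)C(c2ccc(Br)cc2)N=C(SCc2ccc(Cl)cc2)N1`, gives 29.7% in this assay.
Compound 3, `CC1=C(C(=O)Nc2ccc([N+](=O)[O-])cc2)C(c2cccc([N+](=O)[O-])c2)N=C(SCc2cccc(Cl)c2)N1`, gives 17.9% in this assay.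

All three share one core and differ from compound 1 in one place each. From compound 1 to compound 2 the change is 4-chlorophenyl in place of 3-chlorophenyl on a saturated chain carbon bound to a sulfur, and the read-out moved by a number 17.9 percentage points higher from compound 1 to compound 2 (beyond the scatter). From compound 1 to compound 3 the change is 3-nitrophenyl in place of 4-bromophenyl on a saturated ring carbon, and the read-out moved by a number 6.1 percentage points higher from compound 1 to compound 3 (within the scatter), so these two compounds cannot be told apart on this measurement.

Compound 4, `CC1=C(C(=O)Nc2ccc([N+](=O)[O-])cc2)C(c2cccc([N+](=O)[O-])c2)N=C(SCc2ccc(Cl)cc2)N1`, has not yet been measured in this assay. It differs from compound 3 by 4-chlorophenyl in place of 3-chlorophenyl on a saturated chain carbon bound to a sulfur. This is the same change that turns compound 1 into compound 2, at a place described in the same words, so it occurs twice among these four compounds; the two cores on which it is made differ by 3-nitrophenyl in place of 4-bromophenyl on a saturated ring carbon.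

Going by the values given here, for compound 4 the expected step is a number 15.1 percentage points higher from compound 3 to compound 4 (beyond the scatter), which rests on the single earlier instance of this change because that instance gave a number 17.9 percentage points higher from compound 1 to compound 2 (beyond the scatter). Among the compounds with values here, with only one example to lean on, and a read-out whose repeat scatter is wide, the expectation is held loosely. Compound 4 is therefore estimated at 33%, with an expected range from 18% to 48%.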

Compound 4, a percentage reported as inhibition, in the whole organism at one dose (the size of the read-out at that dose, not a potency): 20%
Compound 4: middle estimate off by 13 percentage points, on the high side; the range from low to high includes it.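

Carrying the chlorine shift to the core of compound 3 did not repeat the earlier result in this assay: here the change gives a number 2.1 percentage points higher from compound 3 to compound 4 (within the scatter), and set beside the first instance, the two steps differ: the same change on two cores in this assay, a number 17.9 percentage points higher (beyond the scatter) from compound 1 to compound 2 and a number 2.1 percentage points higher (within the scatter) from compound 3 to compound 4, 15.8 percentage points apart, beyond the scatter of two such steps

The same four compounds can be read the other way, with 3-nitrophenyl in place of 4-bromophenyl on the saturated ring carbon, which gives a number 9.7 percentage points lower from compound 2 to compound 4 (within the scatter), and this change also differs between its two cores: the same change on two cores in this assay, a number 6.1 percentage points higher (within the scatter) from compound 1 to compound 3 and a number 9.7 percentage points lower (within the scatter) from compound 2 to compound 4, 15.8 percentage points apart, beyond the scatter of two such steps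

Both comparisons rest on one set of four compounds, so they are two views of a single finding: in this small set, the step from one change depends on the group at the other place, and a step seen on one core cannot simply be added to another, though the data do not show why this happens or how widely it applies.

As far as these compounds go, it remains open whether the step seen with 4-chlorobenzyl would return with other groups on the saturated ring carbon, such as a plain phenyl or a 4-methoxyphenyl. The result of a plain benzyl or a longer alkyl chain on the sulfur is also unknown, and either could show whether the chlorine shift matters on other cores.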